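From a Phenylethenyl Arm to a Trimethoxyphenyl Arm

This account rests on a few compounds, and the source may have more. Where it says the series, first, only, none or still open, it means among the compounds named here.

Of the compounds shown here, two built on a shared core have been measured in a functional assay on CAKI-1 cells (Homo sapiens) for antiproliferative activity, with a stated time of 48 h; on this read-out higher numbers stand for weaker inhibition of growth and lower numbers for stronger inhibition of growth. Compound 1 `Cc1cc(O)c(C2=NN(c3ccc(S(N)(=O)=O)cc3)C(c3ccccc3O)C2)cc1Cl` carries a 2-hydroxyphenyl group on a saturated ring carbon and gives 1560 nM. Compound 2 `Cc1cc(O)c(C2=NN(c3ccc(S(N)(=O)=O)cc3)C(/C=C/c3ccccc3)C2)cc1Cl` carries a 2-phenylethenyl group at the same place and gives 15300 nM. Compound 2 thus stands at the highest of the two numbers, with compound 1 as its nearest neighbour; the step of a 9.8-fold higher number from compound 1 to compound 2 (0.99 log units; beyond the scatter) shows how far apart they lie.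

Compound 3 `COc1ccc(C2CC(c3cc(Cl)c(C)cc3O)=NN2c2ccc(S(N)(=O)=O)cc2)c(OC)c1OC` has not yet been measured in this assay. It differs from compound 2 in one place: 2,3,4-trimethoxyphenyl in place of 2-phenylethenyl on a saturated ring carbon. Among the compounds with values here, the only measured step that bears on this change is a 9.8-fold higher number from compound 1 to compound 2 (0.99 log units; beyond the scatter), where an aromatic ring sitting directly on the saturated ring carbon was exchanged for the 2-phenylethenyl group and the number rose. Compound 3 brings an aromatic ring back onto that carbon, so the step is expected to run the other way, though the three methoxy groups differ from the hydroxyl of compound 1. The expected step is a 5.1-fold lower number from compound 2 to compound 3 (0.71 log units; beyond the scatter). Compound 3 is estimated at 3000 nM, within a range from 800 nM to 12000 nM.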

Compound 3, concentration for 50% growth inhibition: 2550 nM
Compound 3: middle estimate off by 1.2-fold (0.07 log units), on the high side; low and high end bracket the measured number.
By their numbers in this assay, from the lowest: compounds 1 and 3 (each within the scatter of the next); then compound 2.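

In this assay the exchange gives a 6.0-fold lower number from compound 2 to compound 3 (0.78 log units; beyond the scatter) and the comparison with the remaining compound gives a 1.6-fold higher number from compound 1 to compound 3 (0.21 log units; within the scatter), so a 2,3,4-trimethoxyphenyl group and a 2-hydroxyphenyl group on this saturated ring carbon cannot be told apart in this read-out. Until now, a single aromatic ring on that carbon had been compared with the 2-phenylethenyl group; two differently substituted aromatic rings now both give clearly lower numbers than compound 2, and the hydroxyl of compound 1 proves unnecessary for this level of growth inhibition, as compound 3 has methoxy groups and no such hydroxyl on this ring. Nothing measured here explains these differences.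

As far as these compounds go, it remains open whether an aromatic ring on this carbon matters in itself, which a cyclohexyl ring or a short alkyl chain at the same place would test, and whether an unsubstituted phenyl ring would give a number like those of compound 1 and compound 3. From the compounds shown here alone, it is also open whether the double bond of the 2-phenylethenyl group plays any part, a question that the saturated 2-phenylethyl chain could address.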